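A few compounds are considered here, and "the series" means these few. Any claim that something is new, unique, unknown or untested is made for them only; others in the source may bear on it.

Values from a physicochemical assay for solubility, at pH 7.4 (on this read-out lower numbers stand for lower solubility and higher numbers for higher solubility), so far:
Compound 1 `Cn1cc(C(=O)Nc2ccc(-c3ccccc3)c(C(F)(F)F)c2)c(=O)c2ccncc21`: < 1 ug/mL (a limit of the assay, not a number)
Compound 2 `Cn1cc(C(=O)Nc2ccc(-c3ccccc3)c(C(F)(F)F)c2)c(=O)c2ccccc21`: 1.3 ug/mL
Compound 3 `Cn1cc(C(=O)Nc2ccc(-c3cccnc3)c(C(F)(F)F)c2)c(=O)c2ccccc21`: 23 ug/mL

Of the two real numbers, compound 3 holds the higher. Compound 1 gives only a limit. Compound 4 `Cn1cc(C(=O)Nc2ccc(-c3ccncc3)c(C(F)(F)F)c2)c(=O)c2ccccc21` changes one thing: pyridin-4-yl in place of pyridin-3-yl on an aromatic carbon (pyridin-4-yl in place of pyridin-3-yl, on an aromatic carbon ortho to a trifluoromethyl group). Within the data shown here, only one measured step bears on this: an 18-fold higher number from compound 2 to compound 3 (1.25 log units; beyond the scatter) (pyridin-3-yl in place of phenyl), a large one. That step brought a ring nitrogen in, whereas compound 4 keeps that nitrogen and only moves it. The step expected is therefore a 1.2-fold lower number from compound 3 to compound 4 (0.06 log units; within the scatter) and none beyond the scatter. In this assay the estimate for compound 4 is 20 ug/mL and the expected range runs from 7 ug/mL to 60 ug/mL (both estimated).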

Compound 4, solubility: 6.4 ug/mL
For compound 4 the middle estimate is 3.1-fold (0.49 log units) above the measured one; measured number outside the range, below it.
By their numbers in this assay, from the lowest: compound 2; then compound 4; then compound 3. At a limit, below all of these: compound 1.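

In this assay, where the ring nitrogen sits matters, not only whether it is present: moving it gives a 3.6-fold lower number from compound 3 to compound 4 (0.56 log units; beyond the scatter). The moved nitrogen still keeps part of the rise over the phenyl ring, with a 4.9-fold higher number from compound 2 to compound 4 (0.69 log units; beyond the scatter). On this carbon, ortho to a trifluoromethyl group, the three compounds thus run pyridin-3-yl, then pyridin-4-yl, then phenyl, from the highest number down.

Nothing measured here says why the two pyridine rings differ. From the compounds shown here alone, whether pyridin-2-yl, or a ring carrying an amine, would give a higher number at this position stays open.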